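This account rests on a few compounds, and the source may have more. Where it says the series, first, only, none or still open, it means among the compounds named here.

Measured compounds:
Compound 1, `Cn1cc(C2CC(c3ccccc3)=NN2C(=O)c2cccnc2)c2ccccc21`, in an ADME assay on HEK-293T cells (Homo sapiens) for cytotoxicity, read by MTT assay, with a stated time of 48 h (a higher number here means that more compound is tolerated, a lower number that less compound is tolerated), gives > 300000 nM, which is a limit of the assay.
Compound 2, `COc1ccc(C(=O)N2N=C(c3ccccc3)CC2c2cn(C)c3ccccc23)cn1`, in this assay gives > 300000 nM, likewise a limit.
Compound 3, `COc1ccc(C2=NN(C(=O)c3cccnc3)C(c3cn(C)c4ccc(Br)cc34)C2)cc1`, in this assay gives > 300000 nM, again a limit.

Compound 4, `COc1ccc(C2=NN(C(=O)c3cccnc3)C(c3cn(C)c4ccc(Br)cc34)C2)cc1OC`, is not yet measured. It arises from compound 3 by methoxy in place of hydrogen on an aromatic carbon. The same kind of change, (methoxy in place of hydrogen on an aromatic carbon), connects compound 1 and compound 2, but there it sits on a six-membered aromatic ring with one nitrogen, next to the ring nitrogen and para to a large group, whereas in compound 4 it sits on a six-membered aromatic ring of carbon only, ortho to a methoxy group and meta to a large group. The difference between the core of compound 1 and the core of compound 3 is not broken down here. The step that the two limits leave unreadable from compound 1 to compound 2 cannot be sized because of the limit of > 300000 nM in this assay, at which 3 of the 3 values shown sit. For compound 4 the step of a number no higher from compound 3 to compound 4 (the limit leaves the size open) is expected to be small, an expectation resting on (the limit of > 300000 nM in this assay, at which 3 of the 3 values shown sit). Compound 4 is therefore estimated at 300000 nM, most probably reported once more only as a limit.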

Compound 4, half-maximal cytotoxic concentration: > 300000 nM
Compound 4 gave a limit, no number; the forecaster's own chance of this, stated with the estimate: 85%; the middle value sits exactly at the limit.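

No step can be read between compound 3 and compound 4, because both values are limits and not numbers: the limit of > 300000 nM in this assay, at which 4 of the 4 values shown sit. The compounds shown leave open how much of each is actually tolerated in this assay, and so whether methoxy in place of hydrogen changes anything there.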